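This account rests on a few compounds, and the source may have more. Where it says the series, first, only, none or still open, it means among the compounds named here.

Series notes, cytotoxicity. The common core carries a phenyl ring and two amino groups; the compounds differ in the group attached through the ring nitrogen. Compound 1 `Nc1cc(N)c2nc(-c3ccccc3)c(NCc3ccc(Cl)c(Cl)c3)nc2c1` bears a 3,4-dichlorobenzyl group and in a functional assay on SK-MEL-28 cells (Homo sapiens) for inhibition, read by sulforhodamine B assay, with a stated time of 48 h (a lower number here means that less compound is tolerated, a higher number that more compound is tolerated), compound 1 gives 93300 nM. Compound 3 `COc1cc(CNc2nc3cc(N)cc(N)c3nc2-c2ccccc2)cc(OC)c1OC` carries a 3,4,5-trimethoxybenzyl group, and in this assay compound 3 gives 36300 nM. Of the two numbers available, compound 1 stands highest, and the gap to compound 3 lies beyond the usual scatter. Compound 2 `CCOC(=O)[C@H](CCC(=O)O)NC(=O)c1ccc(Sc2nc3cc(N)cc(N)c3nc2-c2ccccc2)cc1`, with a thioether-linked benzoyl glutamate ethyl ester, gives in this assay only a limit, < 100000 nM; it is the case noted as the limit of < 100000 nM in this assay, at which 1 of the 3 values shown sits, not a number.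

Compound 4 `Nc1cc(N)c2nc(-c3ccccc3)c(NCc3ccc(F)cc3)nc2c1` is the next variant of the benzyl group: 4-fluorophenyl in place of 3,4-dichlorophenyl on a saturated chain carbon bound to a nitrogen on an aromatic ring. Within the data shown here, no measured pair in the set isolates this kind of change, so the size of the step is uncertain. With nothing pointing either way, the expectation for compound 4 is a step from compound 1 of a 1.2-fold lower number from compound 1 to compound 4 (0.07 log units; within the scatter), that is, nothing clearly beyond the scatter. In this assay compound 4 is therefore estimated at 80000 nM, with a plausible range from 30000 nM to 200000 nM, and a real chance that the assay returns only a limit.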

Compound 4, concentration lethal to 50% of the cells: 7410 nM
The estimate for compound 4 lay 11-fold (1.03 log units) above the measured number; measured number outside the range, below it.
By their numbers in this assay, from the lowest: compound 4; then compound 3; then compound 1.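

In this assay, among these compounds, the group on the saturated chain carbon bound to a nitrogen on an aromatic ring can move the number by a wide margin: 4-fluorophenyl in place of 3,4-dichlorophenyl gives a 13-fold lower number from compound 1 to compound 4 (1.10 log units; beyond the scatter) and is the first single change that reads as a measured step. Of the three numbers now available, compound 4 at 7410 nM stands lowest, and compound 3 at 36300 nM lies above it, so the trimethoxybenzyl group no longer marks the low end of this small set. The one supporting note available concerns a different compound and does not bear on this step, so the step remains without an explanation.

The loss of the two chlorines and the arrival of the fluorine change together here, so neither can be credited separately; an unsubstituted phenyl, or a phenyl with one chlorine in place of the fluorine, would pull them apart. From the compounds shown here alone, it also remains open how far the number moves with a different kind of group on that ring, such as an amine or a carboxylic acid.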